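Working notes on the step from compound 1 to compound 3

This account rests on a few compounds, and the source may have more. Where it says the series, first, only, none or still open, it means among the compounds named here.

Compound 1 `COC(=O)CC1CCN(C[C@H]2CN(c3ccc(-n4cc(-c5ccccn5)cn4)c(F)c3)C(=O)O2)CC1` carries the shared core with a 4-((methoxycarbonyl)methyl)piperidin-1-yl group on a saturated chain carbon bound to a saturated ring carbon. In an ADME assay on L02 cells (Homo sapiens) for cytotoxicity, read by MTT assay, with a stated time of 48 h (a higher number here means a weaker inhibitor, a lower number a stronger inhibitor), compound 1 returns only a limit of the assay, > 400 ug/mL. Compound 2 `O=C1O[C@@H](CSc2cccs2)CN1c1ccc(-n2cc(-c3ccccn3)cn2)c(F)c1` differs from compound 1 in one place, with (thiophen-2-yl)sulfanyl in place of that group. In this assay compound 2 likewise returns only a limit, > 400 ug/mL. The step that the two limits leave unreadable from compound 1 to compound 2 cannot be sized because both readings sit at the limit of > 400 ug/mL in this assay, at which 2 of the 2 values shown sit; on the numbers shown, compound 1 stands at the limit and nowhere more precise.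

Compound 3 `O=C(NC[C@H]1CN(c2ccc(-n3cc(-c4ccccn4)cn3)c(F)c2)C(=O)O1)C(F)F` is not yet measured. Its difference from compound 1 is ((difluoromethyl)carbonyl)amino in place of 4-((methoxycarbonyl)methyl)piperidin-1-yl on a saturated chain carbon bound to a saturated ring carbon. For the measured compounds named here, the one measured step changes the same place and gives no readable size, so it carries no direction for the new change. Compound 3 is expected to sit at the limit as well, with the step of a number no higher from compound 1 to compound 3 (the limit leaves the size open) expected to be nothing beyond the scatter. The estimate for compound 3 in this assay is 400 ug/mL, within the range 150 ug/mL to 800 ug/mL.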

Compound 3, half-maximal inhibitory concentration: > 400 ug/mL
Compound 3: no number, only a limit; the forecaster's own chance of this, stated with the estimate: 85%; the middle value lies on the limit itself.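

Compound 3 gives only a limit in this assay, so no step from compound 1 or compound 2 to compound 3 can be read, because all three readings stand at the same limit: the limit of > 400 ug/mL in this assay, at which 3 of the 3 values shown sit.

The compounds shown leave open how compound 1, compound 2 and compound 3 would order in this assay, and whether any group at this place would give a readable value.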